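Swapping the Bicyclic Amide Head on a Sulfonyl Scaffold

The source may report more compounds than this note shows. Statements on the series, on what has been measured and on what is new or still open speak of the compounds shown alone.

Compound 1 `O=C(NCc1ccc(S(=O)(=O)c2ccccc2)cc1)c1nc2cnccc2[nH]1` and compound 2 `O=C(NCc1ccc(S(=O)(=O)c2ccccc2)cc1)c1nc2ccncc2s1` share an amide-linked benzyl sulfone portion and differ only in the bicyclic ring on the carbonyl carbon. In a functional assay on A2780 cells (Homo sapiens) for inhibition, read by sulforhodamine B assay, with a stated time of 72 h (a higher number here means a weaker inhibitor, a lower number a stronger inhibitor), compound 1 gives 5400 nM. For compound 2 this assay records only a limit, > 10000 nM, so compound 2 stands at that floor and nowhere more precisely (the limit of > 10000 nM in this assay, at which 1 of the 2 values shown sits). The step of an at least 1.8-fold higher number from compound 1 to compound 2 (0.26 log units; that floor lies within the scatter) is accordingly a bound rather than a number. Compound 3 `O=C(NCc1ccc(S(=O)(=O)c2ccccc2)cc1)c1cc2cnccc2[nH]1` is the next variation: a group of 9 heavy atoms (7 carbon, 2 nitrogen; one five-membered aromatic ring with 1 hetero atom, one six-membered aromatic ring with 1 hetero atom) in place of a group of 9 heavy atoms (6 carbon, 2 nitrogen, 1 sulfur; one five-membered aromatic ring with 2 hetero atoms, one six-membered aromatic ring with 1 hetero atom), on a carbonyl carbon. Going by the values given here, the only measured step that bears on this change is the one from compound 1 to compound 2, and it fixes no size beyond its floor; the entering bicycle carries 1 hydrogen-bond donor, as the ring of compound 1 does. Compound 3 is therefore expected to sit near the figure of compound 1, estimated at 7000 nM with a range from 2500 nM to 20000 nM. The expected step of an at least 1.4-fold lower number from compound 2 to compound 3 (0.15 log units; that floor lies within the scatter) is an estimate against a limit and cannot be sized more firmly.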

Compound 3, half-maximal inhibitory concentration: 18 nM
The estimate for compound 3 lay 390-fold (2.59 log units) above the measured number; measured number outside the range, below it.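

In this assay, replacing the five-membered aromatic ring with 2 hetero atoms by one with 1 hetero atom gives a 300-fold lower number from compound 1 to compound 3 (2.48 log units; beyond the scatter). Both bicycles carry a hydrogen-bond donor, so a donor alone does not set the number at this position on the carbonyl carbon, which the earlier pair could not show. The change that removes the sulfur-containing bicycle gives an at least 550-fold lower number from compound 2 to compound 3 (2.74 log units; beyond the scatter), and this step is a bound rather than a number, since the value for compound 2 is a limit: the limit of > 10000 nM in this assay, at which 1 of the 3 values shown sits.

The compounds shown leave open whether the number of compound 3 survives a methyl group on the nitrogen of its five-membered ring. They also leave open whether a fluorine or a methoxy group on the bicycle would keep, raise or lower that number.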